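This account rests on a few compounds, and the source may have more. Where it says the series, first, only, none or still open, it means among the compounds named here.

Measured in an ADME assay on microsomes from liver (Mus musculus) for metabolic stability, with a stated time of 10 min; on this read-out higher numbers stand for a more stable compound and lower numbers for a less stable compound:

Compound 1 `O=C(O)[C@H]1CC[C@H](C(=O)N2CC[C@](c3ccc(C(F)(C(F)(F)F)C(F)(F)F)cc3)(S(=O)(=O)c3ccccc3)C2)CC1`: 96%
Compound 2 `O=C(O)[C@H]1CC[C@H](C(=O)N2CC[C@](c3ccc(C(F)(C(F)(F)F)C(F)(F)F)cc3)(S(=O)(=O)c3ccc(Cl)cc3)C2)CC1`: 100%
Compound 3 `COc1ccc(S(=O)(=O)[C@@]2(c3ccc(C(F)(C(F)(F)F)C(F)(F)F)cc3)CCN(C(=O)[C@H]3CC[C@H](C(=O)O)CC3)C2)cc1`: 98%

At 98%, compound 3 sits within the scatter of both other compounds, so the three values cannot be told apart in this assay. The next compound to be tested is compound 4 `CCc1cc(S(=O)(=O)[C@@]2(c3ccc(C(F)(C(F)(F)F)C(F)(F)F)cc3)CCN(C(=O)[C@H]3CC[C@H](C(=O)O)CC3)C2)ccc1F`, and the change is 3-ethyl-4-fluorophenyl in place of 4-methoxyphenyl on a sulfonyl sulfur. Among the compounds with values here, three measured steps bear on this, all of them swaps on the aromatic ring carried by the sulfonyl sulfur. They are a number 4 percentage points higher from compound 1 to compound 2 (within the scatter), a number 2 percentage points higher from compound 1 to compound 3 (within the scatter) and a number 2 percentage points lower from compound 2 to compound 3 (within the scatter). None of these steps leaves the scatter. However, no measured compound carries an ethyl or a fluoro group, so they cover the new 3-ethyl-4-fluorophenyl only in part. No step beyond the scatter is therefore expected in this assay, although the untested groups leave more room on the lower side. The expected step is a number 5 percentage points lower from compound 3 to compound 4 (within the scatter). For compound 4 the estimated value is 93%, with an expected range from 82% to 100%.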

Compound 4, percent of the compound remaining: 73%
For compound 4 the middle estimate is 20 percentage points above the measured one, outside the stated range (below it).
By their numbers in this assay, from the lowest: compound 4; then compounds 1, 3 and 2 (each within the scatter of the next).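

In this assay, within the data shown here, the swap to 3-ethyl-4-fluorophenyl on the sulfonyl sulfur gives a number 25 percentage points lower from compound 3 to compound 4 (beyond the scatter) and so shows that this position can move the read-out, which no earlier step there had done. The same holds against the other two earlier compounds, with a number 27 percentage points lower from compound 2 to compound 4 (beyond the scatter) and a number 23 percentage points lower from compound 1 to compound 4 (beyond the scatter) on record, so the step does not depend on which of the phenyl, 4-chlorophenyl or 4-methoxyphenyl groups serves as the reference. Nothing measured here accounts for this step.

The ethyl and the fluoro enter together, so the compounds shown leave open which of them, or whether only the pair, goes with the lower number, and a phenyl carrying ethyl alone or fluoro alone would separate them. Also open, from the compounds shown here alone, is how a longer chain such as propyl, or an amine on this ring, would read in this assay at this position.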